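A Methyl on the Linker: From Compound 2 to Compound 3

This account rests on a few compounds, and the source may have more. Where it says the series, first, only, none or still open, it means among the compounds named here.

Of the compounds shown here, two have so far been tested in a functional assay on PA-1 cells (Homo sapiens) for cytotoxicity, read by MTT assay, with a stated time of 72 h; a lower number here means a stronger inhibitor, a higher number a weaker inhibitor. Compound 1, `C#CCn1cc(C(=O)NCCCOC(=O)[C@H]2OC(C)(C)N(C(=O)OC(C)(C)C)[C@@H]2c2ccccc2)c(=O)c2ccc(Cl)nc21`, gives 6000 nM in this assay. Compound 2, `C#CCn1cc(C(=O)NCCCOC(=O)[C@H](C)NC(=O)OC(C)(C)C)c(=O)c2ccc(Cl)nc21`, is the other measured compound, and in this assay compound 2 gives > 10000 nM, which is a limit of the assay rather than a measured number. Compound 2 therefore stands at the edge of what this assay can report, as the limit of > 10000 nM in this assay, at which 1 of the 2 values shown sits, records.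

Compound 3, `C#CCn1cc(C(=O)N[C@@H](C)CCOC(=O)[C@H](C)NC(=O)OC(C)(C)C)c(=O)c2ccc(Cl)nc21`, has not yet been measured. It differs from compound 2 by methyl in place of hydrogen on a saturated chain carbon bound to an amide-type nitrogen and a saturated chain carbon. Going by the values given here, no pair among the measured compounds shows what such a change does, so there is no measured step to lean on. A single added methyl on the chain gives little ground to expect a shift beyond the usual scatter, and compound 2 already sits at the limit. The step from compound 2 to compound 3 is expected to be a step that the limit leaves unreadable from compound 2 to compound 3, that is, nothing beyond the scatter. For compound 3 the estimate in this assay is 15000 nM, with a range from 6000 nM to 40000 nM, and the assay is expected most likely to report only a limit again.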

Compound 3, half-maximal inhibitory concentration: 4900 nM
Compound 3: the middle estimate sits 3.1-fold (0.49 log units) above what was measured; measured number below the stated range.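

In this assay, going by these compounds alone, this is the first measured view of what a methyl does on a saturated chain carbon bound to an amide-type nitrogen and a saturated chain carbon, since the earlier compounds offered no step of this kind. Placing it there in place of hydrogen gives an at least 2.0-fold lower number from compound 2 to compound 3 (0.30 log units; that floor lies within the scatter). That floor alone cannot separate a real gain from ordinary variation between repeated measurements, yet it also sets no upper bound, so the true step may be larger, and its size stays unknown because compound 2 is held at a limit of the assay rather than a number: the limit of > 10000 nM in this assay, at which 1 of the 3 values shown sits.

The compounds shown leave open whether methyl is special at this carbon, or whether an ethyl, a hydroxymethyl or an amine there would give a similar number, and what the opposite spatial arrangement of the methyl would do. They also leave open whether the same methyl would move the number in the same direction on compound 1, whose ester part is different.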